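The source may report more compounds than this note shows. Statements on the series, on what has been measured and on what is new or still open speak of the compounds shown alone.

In an ADME assay on Vero cells (Chlorocebus sabaeus) for cytotoxicity, read by neutral red uptake, with a stated time of 48 h (a higher number here means a weaker inhibitor, a lower number a stronger inhibitor), compound 1 `CN(C)c1nc(Cl)nc2c1ncn2CCCNc1ccnc2cc(Cl)ccc12` gives > 11400 nM as a limit of the assay, not a number. Compound 2 `Clc1ccc2c(NCCCn3cnc4c(N5CCCCCC5)nc(Cl)nc43)ccnc2c1` likewise gives > 10100 nM as a limit, so its standing is known only as that limit. For the measured compounds named here, the only measured step, a step that the two limits leave unreadable from compound 1 to compound 2 with azepan-1-yl in place of dimethylamino on an aromatic carbon, has no readable size and so suggests none to expect. Compound 3 `Clc1ccc2c(NCCCn3cnc4c(N5CCN(c6ccccc6)CC5)nc(Cl)nc43)ccnc2c1` has 4-phenylpiperazin-1-yl in place of azepan-1-yl on an aromatic carbon, and 4-phenylpiperazin-1-yl in place of azepan-1-yl on an aromatic carbon counts the change. No shift beyond the scatter is expected, and the estimated step is an at least 1.1-fold lower number from compound 2 to compound 3 (0.05 log units; that floor lies within the scatter) at most a guess. Compound 3 is expected near 9000 nM with an estimated range of 4500 nM to 12000 nM around that figure.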

Compound 3, half-maximal inhibitory concentration: > 8900 nM
Compound 3 was reported as a limit; the forecaster's own chance of this, stated with the estimate: 75%; the middle value lies beyond the limit too.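

For the compounds shown here, compound 1, compound 2 and compound 3 are all reported only as limits, so no step among them can be read. The compounds shown leave open each compound's actual value and whether these group changes shift it.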